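This account rests on a few compounds, and the source may have more. Where it says the series, first, only, none or still open, it means among the compounds named here.

Among the measured compounds shown here, compound 2 `Nc1ccc(-c2nc3cc(Cl)c(Cl)cc3[nH]2)cc1` carries an amino group on an aromatic carbon of the six-membered ring joined to the shared core, and in an ADME assay on MDBK cells (Bos taurus) for cytotoxicity, read by MTT assay, with a stated time of 96 h (on this read-out higher numbers stand for lower toxicity in this test and lower numbers for higher toxicity in this test), compound 2 gives 7500 nM, the highest of the two numbers measured so far. For the measured compounds named here, its nearest neighbour is compound 1 `COc1ccc(-c2nc3cc(Cl)c(Cl)cc3[nH]2)cc1`, which in this assay gives 2500 nM; the only measured step, a 3.0-fold higher number from compound 1 to compound 2 (0.48 log units; beyond the scatter), is the exchange of methoxy for amino on that aromatic carbon. Compound 3 `Oc1ccc(-c2nc3cc(Cl)c(Cl)cc3[nH]2)cc1` differs from compound 2 by hydroxy in place of amino on an aromatic carbon. Going by the values given here, no measured step involves a hydroxy group, so the single step at hand shows only that swapping the group on this aromatic carbon can shift the number by a modest amount in either direction. A step of a 1.5-fold lower number from compound 2 to compound 3 (0.18 log units; within the scatter) is therefore expected, one that should stay within or near the scatter. The estimate for compound 3 is 5000 nM, with a range from 2000 nM to 12000 nM.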

Compound 3, half-maximal cytotoxic concentration: 11000 nM
Compound 3: the middle estimate sits 2.2-fold (0.34 log units) below what was measured, and the stated range covers the measured number.
By their numbers in this assay, from the lowest: compound 1; then compounds 2 and 3 (each within the scatter of the next).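

In this assay the exchange of amino for hydroxy on this aromatic carbon, para to a large group, gives a 1.5-fold higher number from compound 2 to compound 3 (0.17 log units; within the scatter) and so does not separate these two groups. Taking the methyl off the oxygen of the methoxy group gives a 4.4-fold higher number from compound 1 to compound 3 (0.64 log units; beyond the scatter) and, together with the earlier step, sets compound 1 lowest of the three, beyond the scatter from both others, so that among these groups methoxy is the one that stands apart on this carbon. Nothing at hand gives a cause for these shifts.

On these data alone, whether a longer chain such as ethoxy, a carboxylic acid or a fluorine on this carbon would fall with methoxy or with the amino and hydroxy pair stays open. So does whether a methylamino group would behave like methoxy, and whether any of this holds elsewhere on the ring.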